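The compounds below may be only part of what the source reports. "The series", "measured", "known", "first", "only" and "open" are said of these compounds alone.

Measured so far in a physicochemical assay for lipophilicity; a lower number here means a more polar compound, a higher number a more lipophilic compound:
- compound 1, `COC(=O)/C=C(C)/C=C/CC(C)CCCC(C)C`: 6.2
- compound 2, `COC(=O)/C=C(C)/C=C/CC(C)CCCC(C)(C)OC`: 5
- compound 3, `CCOC(=O)/C=C(C)/C=C/CC(C)CCC(OC)C(C)C`: 5.54

Compound 1 stands highest of the three. Compound 3 lies nearest to it, and compound 2 lies furthest, the step being a number 1.20 log units lower from compound 1 to compound 2 (beyond the scatter).

Compound 4, `CCNC(=O)/C=C(C)/C=C/CC(C)CCCC(C)C`, differs from compound 1 in one place: ethylamino in place of methoxy on a carbonyl carbon. Going by the values given here, no measured step touches the carbonyl carbon; the single step known, a number 1.20 log units lower from compound 1 to compound 2 (beyond the scatter), concerns a methoxy added on a saturated chain carbon elsewhere and does not bear on this change. The entering group carries one hydrogen-bond donor where the leaving methoxy carried one acceptor. For compound 4 a downward step is expected, a number 0.80 log units lower from compound 1 to compound 4 (beyond the scatter), of moderate size. Compound 4 is estimated at 5.4, within 4.8 to 6.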

Compound 4, partition coefficient: 5.24
For compound 4 the middle estimate is 0.16 log units above the measured one; the range from low to high includes it.
By their numbers in this assay, from the lowest: compounds 2, 4 and 3 (each within the scatter of the next, the first and the last beyond it); then compound 1.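

In this assay, going by these compounds alone, the carbonyl carbon is a position where a single exchange moves the number: ethylamino in place of methoxy gives a number 0.96 log units lower from compound 1 to compound 4 (beyond the scatter) and is the first step read at this carbon. The change, methoxycarbonyl to ethylcarbamoyl, swaps a hydrogen-bond acceptor for a hydrogen-bond donor, but this step alone cannot separate that swap from the change in chain. No measurement at hand accounts for the size of this step.

As far as these compounds go, how a carboxylic acid or a longer chain on the amide nitrogen would compare at this carbon remains open. So does whether the step would carry over to the methoxy-bearing chain of compound 2.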